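Swapping a phenyl for a chloro on compound 3

The source may hold more compounds than are shown below. What is called first, only, known or untested is meant among the compounds shown, and "the series" means these compounds.

Compound 1 `Cc1cc(C)cc(CN2CCc3ncn(COCc4ccccc4)c3/C(=C/c3ccccc3)C2=O)c1` gives 22500 nM
Compound 2 `Cc1cccc(CN2CCc3ncn(COCc4ccccc4)c3/C(=C/c3ccccc3)C2=O)c1` gives 16100 nM
Compound 3 `O=C1/C(=C\c2ccccc2)c2c(ncn2COCc2ccccc2)CCN1Cc1ccc(-c2ccccc2)cc1` gives 18300 nM

These values come from a functional assay on A549 cells (Homo sapiens) for inhibition, read by MTT assay, with a stated time of 72 h (a higher number here means a weaker inhibitor, a lower number a stronger inhibitor), and they sit close together. Compound 3 cannot be told apart from the other two: the steps are a 1.2-fold lower number from compound 1 to compound 3 (0.09 log units; within the scatter) and a 1.1-fold higher number from compound 2 to compound 3 (0.06 log units; within the scatter) and both lie within the scatter. The next compound is compound 4 `O=C1/C(=C\c2ccccc2)c2c(ncn2COCc2ccccc2)CCN1Cc1ccc(Cl)cc1` which has chloro in place of phenyl on an aromatic carbon, so that 4-phenylphenyl becomes 4-chlorophenyl: chloro in place of phenyl on an aromatic carbon is the full count of that change. The two steps above altered this same aromatic group, and a 1.4-fold lower number from compound 1 to compound 2 (0.15 log units; within the scatter) is a smaller edit on it. None of them goes beyond the scatter. No measured compound carries a chloro group, so this evidence is thin, but it gives no reason to expect a real shift in either direction in this assay for this change. The expected step is a 1.1-fold lower number from compound 3 to compound 4 (0.03 log units; within the scatter) and it is no larger than the scatter. Compound 4 is expected near 17000 nM with 8000 nM to 32000 nM as the estimated range.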

Compound 4, half-maximal inhibitory concentration: 11800 nM
Beside the measured number, compound 4's estimate is 1.4-fold (0.16 log units) above it, within the range that was stated.
By their numbers in this assay, from the lowest: compounds 4, 2, 3 and 1 (each within the scatter of the next).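

Replacing the outer phenyl ring with a single chloro on the same aromatic carbon gives a 1.6-fold lower number from compound 3 to compound 4 (0.19 log units; within the scatter) in this assay, so even this much larger edit at this position does not produce a step that can be told from the scatter. The comparisons with the other two compounds, a 1.4-fold lower number from compound 2 to compound 4 (0.13 log units; within the scatter) and a 1.9-fold lower number from compound 1 to compound 4 (0.28 log units; within the scatter), also stay within the scatter, which places the 4-chlorophenyl compound alongside the 3-methylphenyl, 3,5-dimethylphenyl and 4-phenylphenyl compounds in this assay. No evidence is available that bears on this result.

Still open, going by these compounds, is whether an amine or a carboxylic acid on this aromatic carbon would shift the number beyond the scatter. Also open, on these data alone, is whether a change on the shared core, away from this aromatic group, would do so.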